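Swapping a Sulfonyl Substituent and Watching Clearance

This account rests on a few compounds, and the source may have more. Where it says the series, first, only, none or still open, it means among the compounds named here.

Compound 1 `O=C(Nc1cccc(S(=O)(=O)N2CCCC2)c1)c1cccnc1N1CCC2(CC1)CC2` was run in an ADME assay on microsomes from liver (Homo sapiens) for metabolic stability, read by LC-MS, with a stated time of 40 min, tested at 0.5 uM; on this read-out lower numbers stand for slow clearance and higher numbers for fast clearance. In this assay compound 1 reaches > 399 mL.min-1.g-1, which is a limit of the measurement rather than a number, so compound 1 stands only at the fast end of the values shown (the limit of > 399 mL.min-1.g-1 in this assay, at which 1 of the 2 values shown sits). Compound 2 `CC(C)(C)NS(=O)(=O)c1cccc(NC(=O)c2ncc(NS(C)(=O)=O)nc2N2CCC3(CC2)CC3)n1` gives 127 mL.min-1.g-1 in this assay. Compound 3 `CC(C)(C)NS(=O)(=O)c1cccc(NC(=O)c2cccnc2N2CCC3(CC2)CC3)c1` has not yet been measured; it differs from compound 1 by (tert-butyl)amino in place of pyrrolidin-1-yl on a sulfonyl sulfur. Within the data shown here, no measured step connects these two, so the expected step of an at least 1.3-fold lower number from compound 1 to compound 3 (0.12 log units; that floor lies within the scatter) is a modest drop that may not exceed the usual scatter. Compound 3 is estimated at 300 mL.min-1.g-1, between 150 mL.min-1.g-1 and 600 mL.min-1.g-1.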

Compound 3, intrinsic clearance in microsomes: > 399 mL.min-1.g-1
Compound 3: a limit, no number; the forecaster's own chance of this, stated with the estimate: 35%; at least 1.3-fold (0.12 log units) between middle value and limit.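

Among these compounds, compound 3 gives > 399 mL.min-1.g-1 in this assay, which is a limit and not a number; compound 1 also stands at a limit, so no step between compound 1 and compound 3 can be read. From the compounds shown here alone, whether this swap on the sulfonyl sulfur changes clearance at all stays open.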